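Phenyl to Thiophene at the Benzylic Carbon

A few compounds are considered here, and "the series" means these few. Any claim that something is new, unique, unknown or untested is made for them only; others in the source may bear on it.

Measured so far:
compound 1 `CCCCOc1ccc(C(CC(=O)O)c2ccccc2)cc1`, 1.2 uM
compound 2 `CCCCCOc1ccc(C(CC(=O)O)c2ccccc2)cc1`, 2.97 uM
compound 3 `CCCCOc1ccc(C(CC(=O)O)c2ccc(C(F)(F)F)cc2)cc1`, a limit of > 10 uM

In a functional assay on HEK293 cells for agonist activity at Free fatty acid receptor 1 (Homo sapiens), read by calcium flux (on this read-out higher numbers stand for an effect only at larger amounts of compound and lower numbers for an effect already at smaller amounts), compound 1 gives 1.2 uM, the lowest of the two numbers measured. Compound 2 sits at a 2.5-fold higher number from compound 1 to compound 2 (0.39 log units; beyond the scatter) from it. Compound 3 is reported only as a limit at the limit of > 10 uM in this assay, at which 1 of the 3 values shown sits, and not as a number. The step to the unmeasured compound 4 `CCCCOc1ccc(C(CC(=O)O)c2cccs2)cc1` replaces the ring on the saturated carbon: thiophen-2-yl in place of phenyl on a saturated chain carbon bound to an aromatic carbon and a saturated chain carbon. Within the data shown here, no measured step touches this ring in the same way. The two steps that exist, a 2.5-fold higher number from compound 1 to compound 2 (0.39 log units; beyond the scatter) and an at least 8.3-fold higher number from compound 1 to compound 3 (0.92 log units; beyond the scatter), both add a group elsewhere and both raise the number, but neither swaps one aromatic ring for another, so they give only a loose sense of how much this shared core tolerates. Compound 4 is therefore expected to stay close to compound 1, with an estimated step of a 1.3-fold higher number from compound 1 to compound 4 (0.10 log units; within the scatter) that need not go beyond the scatter. Compound 4 is estimated at 1.5 uM in this assay, within 0.6 uM to 4 uM.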

Compound 4, concentration for half-maximal effect: 1.29 uM
For compound 4 the middle estimate is 1.2-fold (0.07 log units) above the measured one; the range from low to high includes it.
By their numbers in this assay, from the lowest: compounds 1 and 4 (each within the scatter of the next); then compound 2. At a limit, above all of these: compound 3.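

At this position, on a saturated chain carbon bound to an aromatic carbon and a saturated chain carbon, thiophen-2-yl in place of phenyl gives, in this assay, a 1.1-fold higher number from compound 1 to compound 4 (0.03 log units; within the scatter). This is the first step shown that swaps one aromatic ring for another, and unlike the two earlier steps on the shared core it stays within the scatter, so here a five-membered aromatic ring with a sulfur atom and a six-membered aromatic ring of carbon only cannot be told apart by this read-out. The compounds shown offer no reason for this outcome.

As far as these compounds go, whether other rings at this carbon, such as furan-2-yl or a pyridine ring, would fit as well remains open. So does whether thiophen-2-yl behaves the same alongside the longer chain of compound 2.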